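The source may report more compounds than this note shows. Statements on the series, on what has been measured and on what is new or still open speak of the compounds shown alone.

Measured compounds:
compound 1, `COc1ccc2c(O[C@@H]3C[C@H]4C(=O)N[C@]5(C(=O)NS(=O)(=O)C6CC6)C[C@H]5/C=C\CCCCCNC(=O)N4C3)cc(-c3nc(C(C)C)cs3)nc2c1`, 20%;
compound 2, `COc1ccc2c(O[C@@H]3C[C@H]4C(=O)N[C@]5(C(=O)NS(=O)(=O)C6CC6)C[C@H]5/C=C\CCCCN(C)C(=O)N4C3)cc(-c3nc(C(C)C)cs3)nc2c1`, 37%.

In an in vivo ADME assay on the whole organism (strain Sprague-Dawley) for pharmacokinetics, with Rattus norvegicus as the target, at a dose of 10 mg/kg by the oral route (on this read-out higher numbers stand for higher oral bioavailability and lower numbers for lower oral bioavailability), compound 1 gives 20%, the lower of the two numbers recorded. Compound 2 gives 37%, which sits beyond the usual scatter above the value of compound 1. The two compounds differ in more than one place, so their pair says nothing about any single structural change.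

Compound 3, `COc1ccc2c(O[C@@H]3C[C@H]4C(=O)N[C@]5(C(=O)NS(=O)(=O)C6(C)CC6)C[C@H]5/C=C\CCCCCNC(=O)N4C3)cc(-c3nc(C(C)C)cs3)nc2c1`, differs from compound 1 by methyl in place of hydrogen on a saturated ring carbon; the cyclopropylsulfonyl group becomes a (1-methylcyclopropyl)sulfonyl group. No measured pair among the compounds shown isolates this change, so the size of its effect in this assay is not known from the data. Within the data shown here, with only one such small change, the step from compound 1 to compound 3 is expected to be small and upward, estimated as a number 8 percentage points higher from compound 1 to compound 3 (within the scatter), likely within the usual scatter. On that basis compound 3 is expected to give about 28% in this assay, in a range from 12% to 45%.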

Compound 3, oral bioavailability: 54%
Beside the measured number, compound 3's estimate is 26 percentage points below it, outside the stated range (above it).
By their numbers in this assay, from the lowest: compound 1; then compound 2; then compound 3.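

In this assay, methyl in place of hydrogen on a saturated ring carbon of the three-membered ring, which turns the cyclopropylsulfonyl group into a (1-methylcyclopropyl)sulfonyl group, gives a number 34 percentage points higher from compound 1 to compound 3 (beyond the scatter), the only step among these compounds that can be tied to a single change. The earlier pair, compound 1 and compound 2, differs in more than one place and could not speak to any one position, whereas this step shows that the number on this read-out responds strongly to the addition of 1 heavy atom at this ring carbon, with the rest of compound 1 left untouched. No measurement among the data shown accounts for the size of this step, so it stands as an observation without an explanation.

From the compounds shown here alone, whether an ethyl group or a trifluoromethyl group on the same saturated ring carbon would give a higher or a lower number than methyl stays open, as does whether the (1-methylcyclopropyl)sulfonyl group would bring a step of similar size on the core of compound 2. The single read-out also leaves open which part of the handling of these compounds in the rat changes with the methyl group.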